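A few compounds are considered here, and "the series" means these few. Any claim that something is new, unique, unknown or untested is made for them only; others in the source may bear on it.

Working notes on the series. The shared core is that of compound 1 `Cc1ccccc1-n1nc(C)c2c1NC(=O)[C@H](C)S[C@@H]2c1ccc(-c2cccc(C(=O)O)c2)cc1`, in which the distal aryl carries a carboxylic acid; in an assay on isolated protein for agonist activity at Bile acid receptor (Homo sapiens), read by AlphaScreen, with a stated time of 30 min (on this read-out lower numbers stand for an effect already at smaller amounts and higher numbers for an effect only at larger amounts of compound), compound 1 gives "not active" (no number reported), so no number is available for it. Compound 2 `Cc1ccccc1-n1nc(C)c2c1NC(=O)[C@H](C)S[C@@H]2c1ccc(-c2ccsc2)cc1`, with thiophen-3-yl at that position, gives 1400 nM in this assay. Compound 3 `COc1ccccc1-c1ccc([C@H]2S[C@@H](C)C(=O)Nc3c2c(C)nn3-c2ccccc2C)cc1`, with 2-methoxyphenyl, gives 1100 nM in this assay. For the measured compounds named here, the single step with numbers on both sides, a 1.3-fold lower number from compound 2 to compound 3 (0.10 log units; within the scatter), shows that swapping one small aryl for another at this site left the read-out essentially where it was. Compound 3 therefore holds the lowest of the two numbers in this assay, but its gap to compound 2 is within the scatter, so no order between them is claimed.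

Compound 4 `Cc1ccccc1-n1nc(C)c2c1NC(=O)[C@H](C)S[C@@H]2c1ccc(/C=C/c2ccccc2)cc1` is the next variation: 2-phenylethenyl in place of 2-methoxyphenyl on an aromatic carbon. Going by the values given here, no measured step covers a non-aromatic double-bonded linker at this position, so the expectation rests only on the tolerance seen in the step from compound 2 to compound 3 and on the loss of number in compound 1 when a charged acid was placed there. A step of no more than the scatter in this assay is expected, a 1.5-fold higher number from compound 3 to compound 4 (0.16 log units; within the scatter), with some risk that the larger, uncharged extension is less well tolerated. For compound 4 the expected value in this assay is 1600 nM, with a range from 500 nM to 5000 nM.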

Compound 4, half-maximal effective concentration: "not active" (no number reported)
Nothing numeric was reported for compound 4; there is nothing to compare the estimate with.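

In this assay, for the compounds shown here, compound 4 gives "not active" (no number reported), so no step from compound 3 to compound 4 can be read. Nothing available bears on this result. The compounds shown leave open what separates compound 1 and compound 4 from compound 2 and compound 3 at this position.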